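A few compounds are considered here, and "the series" means these few. Any claim that something is new, unique, unknown or untested is made for them only; others in the source may bear on it.

In a functional assay on MDA-MB-231 cells (Homo sapiens) for antiproliferative activity, read by MTT assay, with a stated time of 48 h (a lower number here means a stronger inhibitor, a higher number a weaker inhibitor), three compounds have been measured so far. Compound 1 (`COC(=O)/C(=C/c1ccccc1)CN1C(=O)[C@@H](OC)[C@H]1c1ccc(Cl)cc1`) gives 15600 nM, compound 2 (`CCOC(=O)/C(=C/c1ccccc1)CN1C(=O)[C@@H](OC)[C@H]1c1ccc(Cl)cc1`) gives 11100 nM, and compound 3 (`COC(=O)/C(=C/c1ccccc1)CN1C(=O)[C@@H](OC)[C@H]1c1ccc(Cl)cc1Cl`) gives 19000 nM. Compound 3 lies within the scatter of both others, so the numbers set no order among the three.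

Compound 4 (`COC(=O)/C(=C/c1ccccc1)CN1C(=O)[C@@H](OC)[C@H]1c1ccccc1`) departs from compound 3 in a single place, with phenyl in place of 2,4-dichlorophenyl on a saturated ring carbon. The measured step closest to this change is a 1.2-fold higher number from compound 1 to compound 3 (0.09 log units; within the scatter), where chloro replaces hydrogen on an aromatic carbon of the same aromatic ring. The other step, a 1.4-fold lower number from compound 1 to compound 2 (0.15 log units; within the scatter), lies elsewhere in the molecule and says little about this ring, although it too stays small. Going by these compounds, the chlorine that compound 1 retains has never been removed on its own, so part of the change remains untested. For the measured compounds named here, the one relevant step gives no reason to expect a shift beyond the scatter in this assay, though the untested part calls for a wide range. The expected step is a 1.1-fold lower number from compound 3 to compound 4 (0.05 log units; within the scatter), which would be no real change. For compound 4 the estimated value is 17000 nM, with an expected range from 8000 nM to 36000 nM.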

Compound 4, half-maximal inhibitory concentration: 11100 nM
Compound 4: the middle estimate sits 1.5-fold (0.19 log units) above what was measured; the range from low to high includes it.
By their numbers in this assay, from the lowest: compounds 2, 4, 1 and 3 (each within the scatter of the next).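

The change from 2,4-dichlorophenyl to phenyl on this saturated ring carbon gives a 1.7-fold lower number from compound 3 to compound 4 (0.23 log units; within the scatter) in this assay and so shows that losing both chloro groups together does not move the number beyond the scatter. It also supplies the test that was missing for the chlorine retained in compound 1: hydrogen in place of that chloro gives a 1.4-fold lower number from compound 1 to compound 4 (0.15 log units; within the scatter) and likewise stays within the scatter. Compounds 4, 1 and 3 therefore set no order by their chloro groups, and at this ring carbon the phenyl ring carries the same reading in this assay with or without them.

The compounds shown leave open whether an amine, a hydroxyl group or a carboxylic acid on this aromatic ring, or a pyridine ring or a naphthyl group in place of phenyl, would produce a step beyond the scatter. No supporting measurement is available to explain why these chloro changes leave the number within the scatter.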